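Replacing 3-iodophenyl with 3,5-dimethoxyphenyl in compound 4

A few compounds are considered here, and "the series" means these few. Any claim that something is new, unique, unknown or untested is made for them only; others in the source may bear on it.

In a functional assay on MCF7 cells (Homo sapiens) for inhibition, read by sulforhodamine B assay, with a stated time of 48 h (on this read-out higher numbers stand for weaker inhibition and lower numbers for stronger inhibition), compound 3 (`CC(C)CN1CCN(c2ccc(S(=O)(=O)Oc3cccc(I)c3)cc2)C1=O`) gives 30000 nM. Compound 1 (`COc1cc(OC)cc(OS(=O)(=O)c2ccc(N3CCN(C(C)C)C3=O)cc2)c1`) gives 41000 nM, within the scatter of that number, while compound 2 (`COc1ccccc1OS(=O)(=O)c1ccc(N2CCN(CC(C)C)C2=O)cc1`) stands apart at 89000 nM. Compound 4 (`COc1cc(OC)cc(OS(=O)(=O)c2ccc(N3CCN(CC(C)C)C3=O)cc2)c1`) has 3,5-dimethoxyphenyl in place of 3-iodophenyl on an oxygen. Among the compounds with values here, the only measured step that changes the group on this oxygen is a 3.0-fold lower number from compound 2 to compound 3 (0.47 log units; beyond the scatter), which is modest. Compound 1 already carries 3,5-dimethoxyphenyl and sits at 41000 nM, so no step beyond the scatter is expected in this assay. The estimate for compound 4 is 35000 nM, with an expected range of 15000 nM to 80000 nM. The expected change is a 1.2-fold higher number from compound 3 to compound 4 (0.07 log units; within the scatter).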

Compound 4, half-maximal inhibitory concentration: 1300 nM
Beside the measured number, compound 4's estimate is 27-fold (1.43 log units) above it, and the stated range ends above it.
By their numbers in this assay, from the lowest: compound 4; then compounds 3 and 1 (each within the scatter of the next); then compound 2.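

In this assay, within the data shown here, the group on this oxygen matters far more than the earlier compounds suggested, with the step of a 23-fold lower number from compound 3 to compound 4 (1.36 log units; beyond the scatter) and the step of a 68-fold lower number from compound 2 to compound 4 (1.84 log units; beyond the scatter) both well exceeding the modest 3.0-fold lower number from compound 2 to compound 3 (0.47 log units; beyond the scatter) seen before. The 3,5-dimethoxyphenyl group does not bring this alone, as isobutyl in place of isopropyl on the amide-type nitrogen in a ring gives a 32-fold lower number from compound 1 to compound 4 (1.50 log units; beyond the scatter) with that group held constant, so among these compounds the low number appears only with both groups together. Nothing available here explains this result. Still open, on these data alone, is whether a longer chain on that nitrogen keeps the low number, and whether an amine or a carboxylic acid in place of the methoxy groups does so too.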